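The source may hold more compounds than are shown below. What is called first, only, known or untested is meant among the compounds shown, and "the series" means these compounds.

Among the compounds with values here, in a functional assay on ECa-109 cells (Homo sapiens) for cytotoxicity, read by MTT assay, with a stated time of 72 h (a higher number here means a weaker inhibitor, a lower number a stronger inhibitor), two compounds have numbers so far. Compound 1 `CCC(C)=C1C(=O)N(c2ccc(Cl)cc2)N(c2ccc(Cl)cc2)C1=O` gives 41100 nM and compound 2 `O=C1C(=Cc2ccc(Cl)cc2)C(=O)N(c2ccc(Cl)cc2)N1c1ccc(Cl)cc1` gives 17300 nM as the lower of the two numbers, a gap beyond the usual scatter. Compound 2 thus stands as the stronger inhibitor of this pair, with only compound 1 to compare it against. Compound 3 `COc1cccc(C=C2C(=O)N(c3ccc(Cl)cc3)N(c3ccc(Cl)cc3)C2=O)c1OC` keeps the core of compound 2 and carries 2,3-dimethoxyphenyl in place of 4-chlorophenyl on a double-bonded chain carbon bound to a double-bonded ring carbon. Within the data shown here, no two measured compounds differ in one place only, so nothing measured sizes this change. With compound 2 at 17300 nM as the lower of just two numbers, a modest move toward a higher number, meaning a weaker inhibitor, is expected in this assay and it may stay within the scatter. The estimated change is the step of a 1.4-fold higher number from compound 2 to compound 3 (0.14 log units; within the scatter) on that reading. For compound 3 the expected value is 24000 nM within an estimated range of 8000 nM to 60000 nM for repeated measurements.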

Compound 3, half-maximal inhibitory concentration: 6800 nM
Compound 3: middle estimate off by 3.5-fold (0.55 log units), on the high side; measured number below the stated range.
By their numbers in this assay, from the lowest: compound 3; then compound 2; then compound 1.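

In this assay, within the data shown here, putting 2,3-dimethoxyphenyl in place of 4-chlorophenyl on a double-bonded chain carbon bound to a double-bonded ring carbon gives a 2.5-fold lower number from compound 2 to compound 3 (0.41 log units; beyond the scatter), the first step between measured compounds that differ in one place only, and it lies beyond the usual scatter. It shows that the number in this assay responds to the group at this position, even when the six-membered aromatic ring of carbon is kept and only the groups on that ring change, with the chlorine gone and two methoxy groups present. Nothing measured here explains the step, which stands as an observation on a single pair of compounds. This one pair cannot tell whether the lower number belongs to the 2-methoxy group, the 3-methoxy group or the two together, or whether losing the chlorine plays a part. The compounds shown also leave open how the number would move with an unsubstituted phenyl, a hydroxyl group on the ring, or an amine or a carboxylic acid at this position.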